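This account rests on a few compounds, and the source may have more. Where it says the series, first, only, none or still open, it means among the compounds named here.

Measured so far in an ADME assay on cells (Astrocyte, Homo sapiens) for cytotoxicity, read by WST assay, with a stated time of 72 h; a higher number here means a weaker inhibitor, a lower number a stronger inhibitor:
- Compound 1 `O=C(Nc1ccccc1F)Nc1cc2ncncc2cc1OCc1ccccc1`: > 10000 nM (a limit)
- Compound 2 `O=C(Nc1ccc(C(F)(F)F)cc1)Nc1cc2ncncc2cc1OCc1cccc(Cl)c1`: 8800 nM
- Compound 3 `O=C(Nc1cccc(F)c1)Nc1cc2ncncc2cc1OCc1cccc(Cl)c1`: > 10000 nM (a limit)

Compound 3 gives no number, only the limit > 10000 nM. Its place on the scale is the limit of > 10000 nM in this assay, at which 2 of the 3 values shown sit. Compound 4 `O=C(Nc1ccccc1F)Nc1cc2ncncc2cc1OCc1cccc(Cl)c1` differs from compound 3 in a single group: 2-fluorophenyl in place of 3-fluorophenyl on an amide-type nitrogen. In words, 2-fluorophenyl stands in place of 3-fluorophenyl on an amide-type nitrogen.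

Among the compounds with values here, only one measured step touches this place, an at least 1.1-fold higher number from compound 2 to compound 3 (0.05 log units; that floor lies within the scatter), and its floor lies within the scatter, so it gives no measured size for the change. Compound 1 also carries 2-fluorophenyl, and it too gives only a limit, > 10000 nM. Nothing measured therefore points to a shift in either direction. The expected change is a step that the limit leaves unreadable from compound 3 to compound 4, which would be no step beyond the scatter. Compound 4 is estimated at 12000 nM, with an expected range from 6000 nM to 30000 nM, and the assay will most likely report only a limit.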

Compound 4, half-maximal inhibitory concentration: 8700 nM
For compound 4 the middle estimate is 1.4-fold (0.14 log units) above the measured one; low and high end bracket the measured number.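

With 2-fluorophenyl on the amide-type nitrogen, this assay gives a measured value, and the comparison with 4-(trifluoromethyl)phenyl in that place is a 1.0-fold lower number from compound 2 to compound 4 (0.00 log units; within the scatter), so the two groups are not told apart here. The change from 3-fluorophenyl and the change from hydrogen to chloro give only floors: an at least 1.1-fold lower number from compound 3 to compound 4 (0.06 log units; that floor lies within the scatter), and an at least 1.1-fold lower number from compound 1 to compound 4 (0.06 log units; that floor lies within the scatter). Neither can be read as a size because each starts from a limit: the limit of > 10000 nM in this assay, at which 2 of the 4 values shown sit.

The compounds shown leave open how far the true values of compound 1 and compound 3 lie from that of compound 4. They also leave open whether a phenyl ring bearing an amine or a carboxylic acid on the amide-type nitrogen would move the number beyond the scatter.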